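Ring-opened sulfonamide in the pancreatic cell line series

A few compounds are considered here, and "the series" means these few. Any claim that something is new, unique, unknown or untested is made for them only; others in the source may bear on it.

Compound 1 `CCOC(=O)[C@@H]1CCCN(S(=O)(=O)c2ccc(S(=O)(=O)N3CCCCC3)cc2)C1` is the reference point of this series; in a functional assay on BXPC-3 cells (Homo sapiens) for inhibition, read by MTT assay, with a stated time of 7 days (a higher number here means a weaker inhibitor, a lower number a stronger inhibitor), compound 1 gives 3300 nM. Within the data shown here, it is the only compound with a numeric read-out, since compound 2 `CCOC(=O)N1CCC[C@H](S(=O)(=O)c2ccc(S(=O)(=O)N(CC)CC)cc2)C1` in this assay reaches only a limit of the assay, > 30000 nM, as recorded in the limit of > 30000 nM in this assay, at which 1 of the 2 values shown sits. Among the measured compounds shown here, no step between two measured compounds can be drawn from these two values.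

Compound 3 `CCCN(CC)S(=O)(=O)c1ccc(S(=O)(=O)N2CCC[C@@H](C(=O)OCC)C2)cc1` differs from compound 1 in one place: ethyl(propyl)amino in place of piperidin-1-yl on a sulfonyl sulfur, with the ester-bearing ring left unchanged. For the measured compounds named here, with no measured step available, the expected change from compound 1 to compound 3 is estimated as a 1.4-fold higher number from compound 1 to compound 3 (0.13 log units; within the scatter), a step that should not exceed the usual scatter, leaning if anything toward weaker inhibition. Compound 3 is therefore expected to give about 4500 nM, within 1500 nM to 15000 nM.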

Compound 3, half-maximal inhibitory concentration: 300 nM
Compound 3: the middle estimate sits 15-fold (1.18 log units) above what was measured, outside the stated range (below it).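

In this assay, the group on the sulfonyl sulfur proves to be a sensitive place in the series: ethyl(propyl)amino in place of piperidin-1-yl gives an 11-fold lower number from compound 1 to compound 3 (1.04 log units; beyond the scatter). The two groups match in heavy atoms and in hydrogen-bond counts, so this single step separates a ring from no ring at the same atom count, though it does not establish why the value moves. Compound 2 remains a limit of the assay and adds no step to this reading: the limit of > 30000 nM in this assay, at which 1 of the 3 values shown sits.

Still open, from the compounds shown here alone, is whether the gain follows from opening the ring as such or from this particular pair of ethyl and propyl chains, which a dipropylamino or a pyrrolidin-1-yl group on the same sulfur could separate. Also open, going by these compounds, is what the ethyl ester contributes, for which a carboxylic acid in its place would be informative.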